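The source may hold more compounds than are shown below. What is called first, only, known or untested is meant among the compounds shown, and "the series" means these compounds.

In an ADME assay on HS27 cells (Homo sapiens) for antiproliferative activity, read by sulforhodamine B assay, with a stated time of 48 h (a higher number here means a weaker inhibitor, a lower number a stronger inhibitor), two compounds with a shared core have been tested so far. Compound 1 `O=C(O)c1cc2ccc(-c3ccc(Cl)cc3)cc2n1O` gives only a limit of the assay, > 100000 nM, and not a true number. Going by the values given here, compound 2 `O=C(O)c1cc2ccc(-c3ccc(C(F)(F)F)cc3)cc2n1O` gives 68000 nM, the only true number available. Compound 3 `O=C(O)c1cc2ccc(-c3ccc(-c4ccccc4)cc3)cc2n1O` makes one change to compound 2: phenyl in place of trifluoromethyl on an aromatic carbon. In words, this is phenyl in place of trifluoromethyl on an aromatic carbon.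

Among the compounds with values here, the one measured step that bears on this change is the swap of chloro for trifluoromethyl: an at least 1.4-fold lower number from compound 1 to compound 2 (0.16 log units; that floor lies within the scatter). That step involves a different pair of groups and rests on a limit, so it offers only a weak guide and shows no clear shift. No step beyond the scatter is therefore expected in this assay, and no direction can be favoured with confidence. The expected step is a 1.1-fold lower number from compound 2 to compound 3 (0.05 log units; within the scatter), which would leave the two compounds hard to tell apart. For compound 3, the estimated value is 60000 nM, with an expected range from 22000 nM to 100000 nM.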

Compound 3, half-maximal inhibitory concentration: > 100000 nM
Compound 3: no number, only a limit; the forecaster's own chance of this, stated with the estimate: 35%; middle value at least 1.6-fold (0.22 log units) from the limit.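

At this position, on an aromatic carbon para to a large group, a bigger group with a six-membered aromatic ring does not lower the number in this assay: putting phenyl in place of trifluoromethyl gives an at least 1.4-fold higher number from compound 2 to compound 3 (0.16 log units; that floor lies within the scatter). That floor does not establish a real loss of activity, but compound 3 also gives no sign of the gain that would have shown phenyl to be better tolerated here than trifluoromethyl. The step between compound 1 and compound 3 cannot be read, and most of this small set now sits at the edge of what this assay can report: the limit of > 100000 nM in this assay, at which 2 of the 3 values shown sit.

Going by these compounds, how far compound 3 lies past its limit remains unknown, so phenyl cannot be ranked against chloro or clearly separated from trifluoromethyl. Going by these compounds alone, also open is whether an amine, a carboxylic acid or a longer chain at this position on the shared core would give a number clearly lower than that of compound 2, 68000 nM, which is still the only true value in the set.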